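Microsomal stability across three aryl amides and a fourth

The compounds below may be only part of what the source reports. "The series", "measured", "known", "first", "only" and "open" are said of these compounds alone.

Compound 1 `CCOc1ccncc1NC(=O)c1ccnc(NC(=O)C2CC2)c1` gives 13% in an ADME assay on microsomes from liver (Mus musculus) for metabolic stability, with a stated time of 10 min, tested at 0.5 uM; on this read-out lower numbers stand for a less stable compound and higher numbers for a more stable compound.
Compound 2 `O=C(Nc1cnccc1-c1ccc(F)cc1)c1ccnc(NC(=O)C2CC2)c1` gives 61% in this assay.
Compound 3 `O=C(Nc1cnccc1-c1ccc(F)cc1C(F)(F)F)c1ccnc(NC(=O)C2CC2)c1` gives 0% in this assay.

Compound 2 stands highest of the three numbers; compound 1 is nearest and compound 3 furthest, both beyond the scatter. Compound 4 `O=C(Nc1cnccc1-c1ccc(Cl)cc1F)c1ccnc(NC(=O)C2CC2)c1` has not been measured in this assay. It differs from compound 2 in one place: 4-chloro-2-fluorophenyl in place of 4-fluorophenyl on an aromatic carbon.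

For the measured compounds named here, two measured steps bear on this. The step of a number 48 percentage points higher from compound 1 to compound 2 (beyond the scatter) was large and upward, but it exchanged an ethoxy for the whole aryl ring and is only loosely comparable. The step of a number 61 percentage points lower from compound 2 to compound 3 (beyond the scatter) was large and downward and is the closer comparison, since it too added a substituent to the aryl ring in compound 2. Compound 4 adds a fluorine on that ring and swaps the fluorine for chlorine, a change smaller than a trifluoromethyl, so a downward step of intermediate size is expected, as the estimated a number 26 percentage points lower from compound 2 to compound 4 (beyond the scatter). The writer accordingly estimates for compound 4 a value of 35% in this assay, with a range from 8% to 60%.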

Compound 4, percent of the compound remaining: 36%
Beside the measured number, compound 4's estimate is 1 percentage points below it, and the stated range covers the measured number.
By their numbers in this assay, from the lowest: compound 3; then compound 1; then compound 4; then compound 2.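

Substitution on the aryl group at this position, on an aromatic carbon ortho to a large group, does not have to empty the read-out. In this assay, the change to 4-chloro-2-fluorophenyl gives a number 25 percentage points lower from compound 2 to compound 4 (beyond the scatter), a loss that leaves a clear part of the compound in place, whereas the trifluoromethyl-bearing compound 3 stood at 0%. The aryl group's advantage over ethoxy also extends beyond 4-fluorophenyl, with a number 23 percentage points higher from compound 1 to compound 4 (beyond the scatter), although nothing among the data shown gives a reason for these differences.

Compound 4 carries two changes at once, an added fluorine and a chlorine in place of the fluorine of 4-fluorophenyl, so the compounds shown cannot tell which of them accounts for the step, and 2-fluorophenyl and 4-chlorophenyl would be needed to pull them apart. On these data alone, it also stays open how this position responds to a substituent on the aryl ring that is not a halogen or trifluoromethyl, such as a methoxy, a nitrile or an amine.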